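The compounds below may be only part of what the source reports. "The series", "measured", "known", "first", "only" and "open" are said of these compounds alone.

Three compounds share one core and differ only in the ring on an amine nitrogen. In a functional assay on SK-OV-3 cells (Homo sapiens) for inhibition, read by CCK-8 assay, with a stated time of 70 h (a lower number here means a stronger inhibitor, a higher number a weaker inhibitor), compound 1 `c1ccc(COc2ccc(OCCOCCNC3CCCCC3)cc2)cc1`, which carries cyclohexyl, gives 7370 nM. Compound 2 `c1ccc(COc2ccc(OCCOCCNC3CCC3)cc2)cc1`, which carries cyclobutyl, gives 25000 nM. Compound 3 `c1ccc(COc2ccc(OCCOCCNC3CCCCCC3)cc2)cc1`, which carries cycloheptyl, gives 7460 nM. That places compound 3 level with the cyclohexyl compound, with a 1.0-fold higher number from compound 1 to compound 3 (0.01 log units; within the scatter), and clearly on the stronger side of the cyclobutyl compound, with a 3.4-fold lower number from compound 2 to compound 3 (0.53 log units; beyond the scatter).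

The next structure, compound 4 `c1ccc(COc2ccc(OCCOCCNC3CC3)cc2)cc1`, has cyclopropyl in place of cycloheptyl on an amine nitrogen. Among the measured compounds shown here, the closest guide is the shrinking of the ring in a 3.4-fold higher number from compound 1 to compound 2 (0.53 log units; beyond the scatter), the only measured step that weakens inhibition. No three-membered ring has been measured yet, so the trend must be extended past compound 2 at 25000 nM. A modest weakening, perhaps slightly larger than that step, is therefore expected, an estimated 4.0-fold higher number from compound 3 to compound 4 (0.60 log units; beyond the scatter). Compound 4 is expected at about 30000 nM, within an estimated range from 14000 nM to 60000 nM.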

Compound 4, half-maximal inhibitory concentration: 47200 nM
Compound 4: middle estimate off by 1.6-fold (0.20 log units), on the low side, within the range that was stated.
By their numbers in this assay, from the lowest: compounds 1 and 3 (each within the scatter of the next); then compounds 2 and 4 (each within the scatter of the next).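

In this assay, cyclopropyl on this amine nitrogen gives much weaker inhibition than either larger ring, with a 6.3-fold higher number from compound 3 to compound 4 (0.80 log units; beyond the scatter) and a 6.4-fold higher number from compound 1 to compound 4 (0.81 log units; beyond the scatter). The step down from cyclobutyl, however, shows no real change, with a 1.9-fold higher number from compound 2 to compound 4 (0.28 log units; within the scatter), so shrinking the ring further does not produce a measurable further loss. Across these four compounds, ring size therefore reads as two levels rather than a smooth slope: compound 1 with compound 3 on the stronger side, and compound 2 with compound 4 on the weaker side.

No measurement on hand explains this split. Still open, going by these compounds, is where cyclopentyl would fall relative to these two levels, and whether an open chain such as n-butyl on the same nitrogen would behave like a ring.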